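Thioamidine chain length against the shared core

The source may report more compounds than this note shows. Statements on the series, on what has been measured and on what is new or still open speak of the compounds shown alone.

Compound 3 `N=C(S)CCCCCN1N=C(c2ccccc2)CCC1=O` gives 100 mg/kg in a functional assay on the whole organism (stomach) with Rattus norvegicus as the target (on this read-out higher numbers stand for an effect only at larger amounts of compound and lower numbers for an effect already at smaller amounts), and stands level with compound 1 `N=C(S)CCCCN1N=C(c2ccccc2)CCC1=O`, which gives 100 mg/kg. Compound 2 `N=C(S)CCN1N=C(c2ccccc2)CCC1=O` reaches only a limit of this assay, > 100 mg/kg, and no number. Compound 4 `N=C(S)CCCN1N=C(c2ccccc2)CCC1=O` arises from compound 3 by a group of 3 heavy atoms (1 carbon, 1 nitrogen, 1 sulfur; no ring) in place of a group of 5 heavy atoms (3 carbon, 1 nitrogen, 1 sulfur; no ring), on a saturated chain carbon, three bonds along the chain from an amide-type nitrogen in a ring. Within the data shown here, three measured steps bear on this change: no change at the digits printed from compound 1 to compound 3 (within the scatter), a number no lower from compound 1 to compound 2 (the limit leaves the size open) and a number no higher from compound 2 to compound 3 (the limit leaves the size open). The two steps that touch the shortest chain end at the limit of > 100 mg/kg in this assay, at which 1 of the 3 values shown sits, which leaves their size open. Compound 4 sits in chain length between compound 2 and compound 1, and the step of no change at the digits printed from compound 3 to compound 4 (within the scatter) is expected to be none beyond the scatter or toward a larger dose. Compound 4 is estimated at 100 mg/kg, with a range from 50 mg/kg to 200 mg/kg.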

Compound 4, dose for half-maximal effect: 100 mg/kg
Compound 4: the middle estimate sits on the measured number at the digits printed; the measured number falls inside the stated range.
By their numbers in this assay, from the lowest: compounds 1, 3 and 4 (each within the scatter of the next).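

In this assay, the group of 3 heavy atoms on a saturated chain carbon, three bonds along the chain from an amide-type nitrogen in a ring, gives no change at the digits printed from compound 3 to compound 4 (within the scatter), no change at the digits printed from compound 1 to compound 4 (within the scatter) and a number no higher from compound 2 to compound 4 (the limit leaves the size open). Compounds 1, 3 and 4 therefore stand level across three chain lengths, where only two were level before. Compound 2 remains at a limit of this assay, > 100 mg/kg, and the steps to it cannot be read.

Going by these compounds, whether a longer chain would shift the dose beyond the scatter stays open. So does the effect of an amine or a carboxylic acid in place of the thioamidine end.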